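This account rests on a few compounds, and the source may have more. Where it says the series, first, only, none or still open, it means among the compounds named here.

Compound 3 `Cc1cc(=O)n(-c2ccc(Br)cc2F)nc1C(=O)Nc1ccc(Oc2ncnc3sccc23)c(F)c1` is the subject of this account, which then moves on to compound 4 `Cc1ccc(-n2nc(C(=O)Nc3ccc(Oc4ncnc5sccc45)c(F)c3)c(C)cc2=O)cc1`. In a functional assay on HepG2 cells (Homo sapiens) for cytotoxicity, read by MTT assay, with a stated time of 72 h (on this read-out lower numbers stand for stronger inhibition and higher numbers for weaker inhibition), compound 3 gives 13800 nM, which is the highest of the two numbers measured. Compound 1 `CNC(=O)c1cc(Oc2ccc(NC(=O)c3nn(-c4ccc(C)cc4)c(=O)cc3C)cc2F)ccn1` gives 10600 nM in this assay, and the two values lie within the scatter of each other, so no order between compound 1 and compound 3 can be read from them. Within the data shown here, compound 2 `Cc1ccc(-n2nc(C(=O)Nc3ccc(Oc4ncnc5sccc45)cc3)c(C)cc2=O)cc1` gives only a limit in this assay, > 40000 nM, and not a number; it is the one value sitting at the limit of > 40000 nM in this assay, at which 1 of the 3 values shown sits.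

The change that leads from compound 3 to compound 4 is 4-methylphenyl in place of 4-bromo-2-fluorophenyl on an aromatic nitrogen. Among the measured compounds shown here, no step between two measured compounds shows this exact change, so its size must be estimated rather than read off. Compound 2, which also carries the 4-methylphenyl group on the aromatic nitrogen, gave only a limit in this assay, so a shift toward weaker inhibition beyond the scatter is expected from compound 3 to compound 4, as a 1.8-fold higher number from compound 3 to compound 4 (0.26 log units; within the scatter). The value expected for compound 4 in this assay is therefore 25000 nM, with a range from 10000 nM to 60000 nM, and a fair chance that only a limit is reported.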

Compound 4, half-maximal inhibitory concentration: > 40000 nM
Compound 4 gave a limit, no number (the forecaster's own chance of this, stated with the estimate: 40%); middle value at least 1.6-fold (0.20 log units) from the limit.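

In this assay, replacing 4-bromo-2-fluorophenyl with 4-methylphenyl on the aromatic nitrogen gives an at least 2.8-fold higher number from compound 3 to compound 4 (0.46 log units; beyond the scatter), so this change, with the rest of the structure unchanged, moves the result beyond the scatter, although its full size stays hidden behind the limit reached by compound 4. With 4-methylphenyl present in both compounds, the group on the oxygen on an aromatic ring also counts, since a group of 9 heavy atoms in place of a group of 10 heavy atoms gives an at least 3.7-fold higher number from compound 1 to compound 4 (0.57 log units; beyond the scatter); compound 1 thus shows that 4-methylphenyl on this nitrogen does not by itself lead to a limit. The step between compound 2 and compound 4 cannot be read, and both of these compounds carry a limit and not a number: the limit of > 40000 nM in this assay, at which 2 of the 4 values shown sit.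

The compounds shown do not separate the bromine from the fluorine of the group that leaves, and it remains open how a phenyl group carrying only one of them would compare on this nitrogen. Also open, on these data alone, is where a plain phenyl, a chlorophenyl or an aminophenyl group would fall on this read-out.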